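A few compounds are considered here, and "the series" means these few. Any claim that something is new, unique, unknown or untested is made for them only; others in the source may bear on it.

Measured so far:
- compound 1 `COc1cccc(NC(=O)COc2ccc3cc(/C=C4/SC(=O)NC4=O)ccc3c2)c1`: 1600 nM
- compound 2 `COc1ccc(NC(=O)COc2ccc3cc(/C=C4/SC(=O)NC4=O)ccc3c2)cc1`: 4700 nM

Both compounds were tested in an assay on isolated protein for inhibition of histone deacetylase 4 (Homo sapiens), with a stated time of 1 h; a lower number here means a stronger inhibitor, a higher number a weaker inhibitor. Compound 2 stands as the higher of the two numbers: the step of a 2.9-fold higher number from compound 1 to compound 2 (0.47 log units; beyond the scatter) shows what moving the methoxy group from one position to the other on the amide-type nitrogen did.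

Compound 3 `O=C(COc1ccc2cc(/C=C3/SC(=O)NC3=O)ccc2c1)Nc1cccc(Cl)c1` has not yet been measured. It differs from compound 2 in one place: 3-chlorophenyl in place of 4-methoxyphenyl on an amide-type nitrogen. Going by the values given here, no measured step tests a chlorine in this position, so only the single step from compound 1 to compound 2 bears on it, and only indirectly, by showing that a group placed as in compound 1 gave the lower number.

On that basis the number for compound 3 is expected to come out lower than for compound 2, and the step expected is a 2.4-fold lower number from compound 2 to compound 3 (0.37 log units; beyond the scatter). The estimate for compound 3 in this assay is 2000 nM, with a range from 600 nM to 6500 nM.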

Compound 3, half-maximal inhibitory concentration: 3800 nM
Beside the measured number, compound 3's estimate is 1.9-fold (0.28 log units) below it, within the range that was stated.
By their numbers in this assay, from the lowest: compound 1; then compounds 3 and 2 (each within the scatter of the next).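

In this assay, 3-chlorophenyl in place of 4-methoxyphenyl on the amide-type nitrogen gives a 1.2-fold lower number from compound 2 to compound 3 (0.09 log units; within the scatter), so these two groups cannot be told apart here. The more informative comparison keeps the substituent's place and exchanges only the group: chloro in place of methoxy on an aromatic carbon gives a 2.4-fold higher number from compound 1 to compound 3 (0.38 log units; beyond the scatter) and shows that the lower number of compound 1 does not carry over to every 3-substituted phenyl, so the identity of the group matters as well as its place. Nothing available explains why methoxy and chloro differ here.

Going by these compounds, it remains open how 4-chlorophenyl would compare with 4-methoxyphenyl, which would show whether the two groups differ in the same way at both places. Also open, on these data alone, is whether a plain phenyl, a 3-aminophenyl or a 3-carboxyphenyl would give a number lower than that of compound 1.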